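Adding a Methyl Group to Compound 2

The compounds below may be only part of what the source reports. "The series", "measured", "known", "first", "only" and "open" are said of these compounds alone.

In an ADME assay on HuDe cells (Homo sapiens) for cytotoxicity, read by MTT assay, with a stated time of 72 h (a higher number here means a weaker inhibitor, a lower number a stronger inhibitor), compound 1 `NC(=O)c1cc(Cl)ccc1NC(=O)COc1ccccc1` gives 808000 nM, while compound 2 `NC(=O)c1cc(I)ccc1NC(=O)COc1ccccc1` gives 318000 nM. Compound 2 therefore holds the lower of the two numbers and is the stronger inhibitor of this pair.

The next compound to be tested is compound 3 `Cc1ccc(OCC(=O)Nc2ccc(I)cc2C(N)=O)cc1`. Its structure differs from that of compound 2 at one place: methyl in place of hydrogen on an aromatic carbon. In words, this is methyl in place of hydrogen on an aromatic carbon, turning phenyl into 4-methylphenyl.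

Among the compounds with values here, the only measured step is a 2.5-fold lower number from compound 1 to compound 2 (0.40 log units; beyond the scatter), which comes from iodo in place of chloro on an aromatic carbon. Within the data shown here, that is a different change, and no measured pair shows what adding a methyl does, so the evidence here is indirect. The step seen for compound 2 serves only as a rough guide to size. A small move towards a lower number in this assay is expected, possibly none beyond the scatter.

The expected change is a 1.3-fold lower number from compound 2 to compound 3 (0.10 log units; within the scatter). For compound 3, the estimated value is 250000 nM, within an expected range of 120000 nM to 500000 nM.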

Compound 3, half-maximal inhibitory concentration: 356000 nM
For compound 3 the middle estimate is 1.4-fold (0.15 log units) below the measured one; the range from low to high includes it.
By their numbers in this assay, from the lowest: compounds 2 and 3 (each within the scatter of the next); then compound 1.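

In this assay, turning phenyl into 4-methylphenyl gives a 1.1-fold higher number from compound 2 to compound 3 (0.05 log units; within the scatter) and so yields no readable difference between the two compounds. Within the data shown here, this is the first measured change on this six-membered aromatic ring of carbon only, and at this place, para to a large group, one added methyl is tolerated without a shift that can be told from the ordinary spread of repeated measurements; the earlier swap of iodo for chloro, by contrast, gave a 2.5-fold lower number from compound 1 to compound 2 (0.40 log units; beyond the scatter) and did move the number beyond that spread. Nothing measured here offers an explanation for either outcome.

On these data alone, a single small group tests this place only lightly, and it remains open whether an amine, a carboxylic acid or a longer chain such as butyl at the same spot would leave the number just as unchanged or move it clearly. As far as these compounds go, it is also open whether the methyl would behave the same way on compound 1, which carries chloro instead of iodo.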